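The compounds below may be only part of what the source reports. "The series", "measured", "known", "first", "only" and "open" are said of these compounds alone.

Measured so far:
compound 1 `C[C@H](Nc1ncnc2[nH]cnc12)c1nn(-c2ccc(C#N)cc2)c2cc(F)ccc12` — 57% in a functional assay on HepG2 cells (Homo sapiens) for inhibition, read by sulforhodamine B assay, with a stated time of 72 h, tested at 10 uM; a higher number here means more inhibition at the concentration tested (going by the name of the read-out), a lower number less inhibition
compound 2 `C[C@H](Nc1ncnc2[nH]cnc12)c1nn(-c2cccc(S(C)(=O)=O)c2)c2cc(F)ccc12` — 23%

Among the compounds with values here, compound 2 gives the lowest of the two numbers in this assay; its nearest neighbour is compound 1, and the only step known, a number 34 percentage points lower from compound 1 to compound 2 (beyond the scatter), is large and beyond the scatter. Compound 3 `C[C@H](Nc1ncnc2[nH]cnc12)c1nn(-c2cc(F)cc(F)c2)c2cc(F)ccc12` is not yet measured. It differs from compound 2 only at the aromatic nitrogen: 3,5-difluorophenyl in place of 3-(methylsulfonyl)phenyl on an aromatic nitrogen. Within the data shown here, no step between two measured compounds involves a 3,5-difluorophenyl group at this place, so the single step from compound 1 to compound 2 is the only guide, and it shows that exchanging the ring on this nitrogen can move the number a great deal. A step of some size in either direction is therefore possible. The estimate for compound 3 is 38% (range 15% to 62%), which would be a step of a number 15 percentage points higher from compound 2 to compound 3 (beyond the scatter) from compound 2 and is expected only loosely.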

Compound 3, a percentage reported as inhibition, at one concentration (the size of the read-out at that concentration, not a potency): 30%
Beside the measured number, compound 3's estimate is 8 percentage points above it; measured number inside the range.
By their numbers in this assay, from the lowest: compounds 2 and 3 (each within the scatter of the next); then compound 1.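

In this assay, the exchange of 3-(methylsulfonyl)phenyl for 3,5-difluorophenyl on the aromatic nitrogen comes to a number 7 percentage points higher from compound 2 to compound 3 (within the scatter), so these two rings, which carry quite different groups, cannot be told apart here. Replacing 4-cyanophenyl with 3,5-difluorophenyl gives a number 27 percentage points lower from compound 1 to compound 3 (beyond the scatter), which shows that the loss seen earlier is not confined to the methylsulfonyl group: among the three rings on this nitrogen, only the 4-cyanophenyl ring of compound 1 stands apart, beyond the scatter from both others. No measurement offers an explanation for this pattern. Going by these compounds, whether the number of compound 1 belongs to the nitrile itself or to where it sits on the phenyl ring remains open. Also open, on these data alone, is what a 3-cyanophenyl group, or a phenyl ring bearing an amine or a carboxylic acid, would give on this nitrogen.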